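The source may report more compounds than this note shows. Statements on the series, on what has been measured and on what is new or still open speak of the compounds shown alone.

Measured so far:
- compound 1, `COc1cc(NC(C)CCCNC(=O)NNC(=O)Nc2cc(C(F)(F)F)cc(C(F)(F)F)c2)c2ncccc2c1` — in a functional assay on MIA PaCa-2 cells (Homo sapiens) for inhibition, read by MTT assay, with a stated time of 72 h (a lower number here means a stronger inhibitor, a higher number a weaker inhibitor), compound 1 gives 20000 nM
- compound 2, `COc1cc(NC(C)CCCNC(=O)NNC(=O)Nc2ccc(O)cc2)c2ncccc2c1` — in this assay compound 2 gives 142000 nM

Of the two numbers, compound 2 has the higher one, so it is the weaker inhibitor of the pair; its nearest neighbour is compound 1, and the gap between them is beyond the usual scatter of repeated measurements.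

The next compound, compound 3, is `COc1cc(NC(C)CCCNC(=O)Nc2cccc(C(F)(F)F)c2)c2ncccc2c1`. It is built on the same core as compound 2 and differs in one place: 3-(trifluoromethyl)phenyl in place of ((4-hydroxyphenyl)carbamoyl)amino on an amide-type nitrogen. The change shortens the chain end and removes the hydrogen-bond donors and acceptors counted there.

Within the data shown here, no measured pair shows this exact change, so the expected step rests on what the two measured compounds show. Because compound 1, whose end carries trifluoromethyl groups, gives 20000 nM while compound 2 gives 142000 nM, the step from compound 2 to compound 3 is expected to be a 5.7-fold lower number from compound 2 to compound 3 (0.75 log units; beyond the scatter), toward a lower number. Compound 3 is thus estimated at 25000 nM, with a likely range from 6000 nM to 100000 nM.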

Compound 3, half-maximal inhibitory concentration: 17000 nM
For compound 3 the middle estimate is 1.5-fold (0.17 log units) above the measured one; measured number inside the range.
By their numbers in this assay, from the lowest: compounds 3 and 1 (each within the scatter of the next); then compound 2.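

Among these compounds, on the amide-type nitrogen whose other neighbour is a carbonyl carbon, putting 3-(trifluoromethyl)phenyl in place of ((4-hydroxyphenyl)carbamoyl)amino gives an 8.4-fold lower number from compound 2 to compound 3 (0.92 log units; beyond the scatter) in this assay, the only step so far between compounds that differ in one place. The shorter end, with no hydrogen-bond donors or acceptors counted in it, gives a number within the scatter of the longer end of compound 1: compound 1 gives 20000 nM and compound 3 gives 17000 nM, so among these compounds the longer end is not needed to reach this level. No evidence is at hand to say what lies behind the step.

This one swap changes both the length of the end and the group on its aromatic ring, so the compounds shown cannot separate the contribution of each. An unsubstituted phenyl or a 3-chlorophenyl on the same nitrogen would help to show whether trifluoromethyl itself matters, and a 3-aminophenyl or 3-carboxyphenyl would extend the range of groups tested at this position.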